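Swapping the acid-bearing ring on a cyclopropane

This account rests on a few compounds, and the source may have more. Where it says the series, first, only, none or still open, it means among the compounds named here.

Compound 1 `O=C(O)c1cccc([C@H]2C[C@@H]2c2ccc(OCc3c(-c4c(Cl)cccc4Cl)noc3C3CC3)cc2Cl)c1`: 88%
Compound 2 `CC(C)n1nc(C(=O)O)cc1C1CC1c1ccc(OCc2c(-c3c(Cl)cccc3Cl)noc2C2CC2)cc1Cl`: 81%

Of the compounds shown here, two with a shared core have been measured. In an assay on HEK293 cells for agonist activity at Bile acid receptor (Homo sapiens) (a higher number here means a larger maximal response, a lower number a smaller maximal response), compound 1 gives 88%, and compound 2 gives 81%. Compound 2 holds the lower of the two numbers, but the nearest value, that of compound 1, lies within the scatter of the measurement, so the two cannot be placed in an order. Among the compounds with values here, no step between the measured compounds has been worked out.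

Compound 3 `O=C(O)c1ccc(C2CC2c2ccc(OCc3c(-c4c(Cl)cccc4Cl)noc3C3CC3)cc2Cl)cn1` has not yet been measured. It differs from compound 2 in one place: 6-carboxypyridin-3-yl in place of 3-carboxy-1-isopropyl-1H-pyrazol-5-yl on a saturated ring carbon. Both measured compounds carry a carboxylic acid on an aromatic ring attached to the saturated ring carbon of the three-membered ring, and both reach a large maximal response; compound 3 keeps such an acid-bearing aromatic ring. Within the data shown here, with no measured step to lean on, the step of a number 4 percentage points higher from compound 2 to compound 3 (within the scatter) is expected to be none beyond the scatter. Compound 3 is therefore estimated to give 85%, with a range from 65% to 100%.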

Compound 3, largest response reached (reported as efficacy), in percent of the reference or control that the assay uses: 68%
Compound 3: the middle estimate sits 17 percentage points above what was measured, and the stated range covers the measured number.
By their numbers in this assay, from the lowest: compound 3; then compounds 2 and 1 (each within the scatter of the next).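

Within this assay, the acid-bearing aromatic ring on the cyclopropane proves not to be freely interchangeable: 6-carboxypyridin-3-yl in place of 3-carboxy-1-isopropyl-1H-pyrazol-5-yl gives a number 13 percentage points lower from compound 2 to compound 3 (beyond the scatter) and 2-(6-carboxypyridin-3-yl)cyclopropyl in place of 2-(3-carboxyphenyl)cyclopropyl gives a number 20 percentage points lower from compound 1 to compound 3 (beyond the scatter) (both beyond the usual scatter). A carboxylic acid on an aromatic ring at this carbon is therefore not enough on its own to hold the maximal response at the level seen for compound 1 and compound 2, although the response of compound 3 is lowered here and not lost. No measurement is available that explains this drop.

Each step changes the ring as a whole, so the compounds shown cannot separate the effect of ring size, ring nitrogen, the isopropyl group or where the acid sits on the ring. On these data alone, it also remains open how this position would respond if the carboxylic acid were replaced by a tetrazole or a primary amide, or if the ring carried a methyl ester instead.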